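Tert-butyl in place of isopropoxy on the carbonyl carbon

A few compounds are considered here, and "the series" means these few. Any claim that something is new, unique, unknown or untested is made for them only; others in the source may bear on it.

Measured so far in an assay on HEK293 cells for displacement of a labelled ligand from Melanocortin receptor 4 (Homo sapiens); on this read-out lower numbers stand for stronger inhibition and higher numbers for weaker inhibition:
compound 1 `Cc1ccc(N2CCN(C(=O)[C@@H]3[C@@H](c4ccc(Cl)cc4)CCN3C(=O)OC(C)C)CC2)c([C@@H](N)C(C)C)c1`: 68 nM
compound 2 `Cc1ccc(N2CCN(C(=O)[C@H]3[C@@H](c4ccc(Cl)cc4)CCN3C(=O)OC(C)C)CC2)c([C@@H](N)C(C)C)c1`: 12 nM

Among the measured compounds shown here, compound 1 stands at the higher of the two numbers; its only neighbour is compound 2, reached by the step of a 5.7-fold lower number from compound 1 to compound 2 (0.75 log units; beyond the scatter), a step that rests on (the fact that compounds 1 and 2 differ only in the configuration as drawn). For the measured compounds named here, the saturated-ring configuration therefore moves the number by a modest amount, but nothing measured so far touches the group on the carbonyl carbon.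

Compound 3 `Cc1ccc(N2CCN(C(=O)[C@@H]3[C@@H](c4ccc(Cl)cc4)CCN3C(=O)C(C)(C)C)CC2)c([C@@H](N)C(C)C)c1` differs from compound 1 by tert-butyl in place of isopropoxy on a carbonyl carbon. Going by the values given here, no measured step bears on this change: the single step available, from compound 1 to compound 2, alters configuration only. The expectation for compound 3 is thus set near compound 1, with no step beyond the scatter foreseen and a wide range to cover the unknown. Compound 3 is expected to give 80 nM, between 25 nM and 250 nM. That estimate amounts to an expected step of a 1.2-fold higher number from compound 1 to compound 3 (0.07 log units; within the scatter).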

Compound 3, inhibition constant: 79 nM
Compound 3: middle estimate off by 1.0-fold (0.01 log units), on the high side, within the range that was stated.
By their numbers in this assay, from the lowest: compound 2; then compounds 1 and 3 (each within the scatter of the next).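

In this assay the exchange gives a 1.2-fold higher number from compound 1 to compound 3 (0.07 log units; within the scatter) and so separates isopropoxy from tert-butyl on this carbonyl carbon by no more than the usual scatter. On the core of compound 1, an all-carbon group of the same heavy-atom count therefore holds the number as well as the isopropoxy with its oxygen does, so that oxygen is not needed to keep the number in this range. No available evidence bears on this step.

Going by these compounds, whether the same exchange reads alike on the configuration of compound 2 stays open. Also open, on these data alone, is how the number responds when this carbonyl carbon carries a dimethylamino group, a phenyl ring or a longer chain such as n-butyl in place of tert-butyl.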